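The compounds below may be only part of what the source reports. "The series", "measured", "known", "first", "only" and "open" are said of these compounds alone.

Of the compounds shown here, two sharing one core have been measured so far in a functional assay on MDA-MB-231 cells (Homo sapiens) for inhibition, read by MTT assay, with a stated time of 48 h; on this read-out lower numbers stand for stronger inhibition of growth and higher numbers for weaker inhibition of growth. Compound 1 `Cc1cccc(Nc2ncnc3ccc(NC(=S)NCc4ccccc4)cc23)c1` gives 19500 nM, and compound 2 `CC(C)(C)c1ccc(Nc2ncnc3ccc(NC(=S)NCc4ccccc4)cc23)cc1` gives 8700 nM, the lower of the two numbers. Among the compounds with values here, the only measured step is a 2.2-fold lower number from compound 1 to compound 2 (0.35 log units; beyond the scatter), and it is modest. Compound 3 `Oc1cccc(Nc2ncnc3ccc(NC(=S)NCc4ccccc4)cc23)c1` keeps the shared core and changes the same group again: 3-hydroxyphenyl in place of 4-(tert-butyl)phenyl on a nitrogen on an aromatic ring. Here 3-hydroxyphenyl stands in place of 4-(tert-butyl)phenyl on a nitrogen on an aromatic ring. Within the data shown here, the one measured step bears on this only in part, since 4-(tert-butyl)phenyl is again involved but its partner there was 3-methylphenyl. Among the measured compounds shown here, no compound with a 3-hydroxyphenyl group has a measured value yet. Going by the modest size of a 2.2-fold lower number from compound 1 to compound 2 (0.35 log units; beyond the scatter), a step of similar size is expected in this assay, towards a higher number and back into the region of compound 1 at 19500 nM, though with wide uncertainty. The estimate amounts to an expected 1.8-fold higher number from compound 2 to compound 3 (0.26 log units; within the scatter). For compound 3 the estimated value is 16000 nM, with an expected range from 6000 nM to 40000 nM.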

Compound 3, concentration for 50% growth inhibition: > 30000 nM
Compound 3 gave a limit, no number; the forecaster's own chance of this, stated with the estimate: 10%; middle value at least 1.8-fold (0.27 log units) from the limit.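

In this assay compound 3 gives > 30000 nM, which is a limit of the assay and not a number: the limit of > 30000 nM in this assay, at which 1 of the 3 values shown sits.

Within the data shown here, at the aromatic nitrogen, 3-hydroxyphenyl in place of 4-(tert-butyl)phenyl gives an at least 3.4-fold higher number from compound 2 to compound 3 (0.53 log units; beyond the scatter), so this position has now moved the read-out towards weaker inhibition of growth as well as towards stronger inhibition, and 4-(tert-butyl)phenyl stays the only group here with a step to a lower number. Hydroxy in place of methyl on an aromatic carbon gives an at least 1.5-fold higher number from compound 1 to compound 3 (0.18 log units; that floor lies within the scatter), and since that floor lies within the scatter, no order between these two compounds can be read from it.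

From the compounds shown here alone, how far compound 3 really lies from compound 1 stays open, as does the question of whether the weaker growth inhibition goes with the hydroxy group itself or with the loss of the 4-(tert-butyl)phenyl group. A methoxy or an amino group in place of that hydroxy on the aromatic carbon would bear on this, and the compounds shown say nothing about either group.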